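Substituent swap on the five-membered aromatic ring: cyclopropyl for methylsulfanyl

This account rests on a few compounds, and the source may have more. Where it says the series, first, only, none or still open, it means among the compounds named here.

Measured so far in a functional assay on CHO cells for antagonist activity at Orexin receptor type 2 (Homo sapiens), read by FLIPR and calcium flux; on this read-out lower numbers stand for stronger inhibition and higher numbers for weaker inhibition:
compound 1, `CCc1nc(C(F)(F)F)c2n1CCN([C@@H](C(=O)NC)c1ccccc1)[C@H]2CCc1ccc(C(F)(F)F)cc1`, gives 11 nM;
compound 2, `CCc1nc(SC)c2n1CCN([C@@H](C(=O)NC)c1ccccc1)[C@H]2CCc1ccc(C(F)(F)F)cc1`, gives 14 nM.

Compound 2 stands at the higher of the two numbers, yet the gap to compound 1 is small: a 1.3-fold higher number from compound 1 to compound 2 (0.10 log units; within the scatter). Both values therefore sit together, and no order between compound 1 and compound 2 can be read from them.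

The next compound, compound 3, `CCc1nc(C2CC2)c2n1CCN([C@@H](C(=O)NC)c1ccccc1)[C@H]2CCc1ccc(C(F)(F)F)cc1`, differs from compound 2 at the same position: cyclopropyl in place of methylsulfanyl on an aromatic carbon. Within the data shown here, the only step that bears on this position is the exchange from compound 1 to compound 2, and it stayed inside the scatter. Two different groups at this position have thus given near-identical readings in this assay, so a third group is not expected to move the number beyond the scatter in either direction; the step from compound 2 to compound 3 is estimated as a 1.1-fold higher number from compound 2 to compound 3 (0.03 log units; within the scatter). Compound 3 is accordingly expected to give about 15 nM in this assay, with a likely range from 6 nM to 40 nM.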

Compound 3, half-maximal inhibitory concentration: 29 nM
The estimate for compound 3 lay 1.9-fold (0.29 log units) below the measured number; low and high end bracket the measured number.
By their numbers in this assay, from the lowest: compounds 1 and 2 (each within the scatter of the next); then compound 3.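

In this assay this position no longer looks indifferent to its substituent: replacing methylsulfanyl with cyclopropyl gives a 2.1-fold higher number from compound 2 to compound 3 (0.32 log units; beyond the scatter), and replacing trifluoromethyl with cyclopropyl gives a 2.6-fold higher number from compound 1 to compound 3 (0.42 log units; beyond the scatter). Both steps are modest but lie beyond the scatter, so compound 1 and compound 2 stay together while compound 3, the only one of the three carrying a ring at this position, stands apart on the side of weaker inhibition. Nothing available on these compounds accounts for this shift.

Three groups cannot show whether the shift belongs to the three-membered ring itself or to some other difference between the groups, and an isopropyl group or a cyclobutyl ring at this position would offer the closest comparison. Also open, as far as these compounds go, is whether a hydrogen, a nitrile or an amine here would stay with compound 1 and compound 2, or would move the number further from them than cyclopropyl does.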